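Moving a chlorine on the benzyl group of a hydrazone

This account rests on a few compounds, and the source may have more. Where it says the series, first, only, none or still open, it means among the compounds named here.

Measured so far in a functional assay on ECa-109 cells (Homo sapiens) for antiproliferative activity, read by MTT assay, with a stated time of 72 h; a higher number here means a weaker inhibitor, a lower number a stronger inhibitor:
Compound 1 `CCCSc1nc(N/N=C/c2ccccc2Cl)c2nnn(Cc3ccccc3)c2n1` gives 6180 nM.
Compound 2 `CCCSc1nc(N/N=C(\C)c2ccccc2O)c2nnn(Cc3ccccc3Cl)c2n1` gives > 64000 nM, which is a limit of the assay and not a number.

Compound 2 therefore stands at the edge of what the assay can report, as shown by the limit of > 64000 nM in this assay, at which 1 of the 2 values shown sits. Compound 3 `CCCSc1nc(N/N=C(\C)c2ccccc2O)c2nnn(Cc3cccc(Cl)c3)c2n1` has not yet been measured; it differs from compound 2 by 3-chlorophenyl in place of 2-chlorophenyl on a saturated chain carbon bound to an aromatic nitrogen. Going by the values given here, no step between measured compounds is available to guide the size of this change, so nothing beyond the usual scatter is expected. The step of an at least 1.0-fold lower number from compound 2 to compound 3 (0.02 log units; that floor lies within the scatter) is expected to be roughly flat. Compound 3 is estimated at 60000 nM, expected to fall between 15000 nM and 200000 nM.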

Compound 3, half-maximal inhibitory concentration: 13000 nM
Estimate against measurement, compound 3: 4.6-fold (0.66 log units) above, and the stated range ends above it.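

Moving the chlorine from 2-chlorobenzyl to 3-chlorobenzyl gives an at least 4.9-fold lower number from compound 2 to compound 3 (0.69 log units; beyond the scatter) in this assay and so shows that the place of this one chlorine on the ring can alone shift the result beyond the scatter. The atoms stay the same, and only how they are joined changes. Compound 2 carries a limit and not a number, so the true step may be larger than this floor: the limit of > 64000 nM in this assay, at which 1 of the 3 values shown sits.

Going by these compounds, whether 4-chlorobenzyl or an amine on the benzyl ring would change the result further remains open. Compound 1 differs from compound 2 and compound 3 in more than one place, so it cannot settle this.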